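Turning one stereocentre in compound 1

A few compounds are considered here, and "the series" means these few. Any claim that something is new, unique, unknown or untested is made for them only; others in the source may bear on it.

Among the measured compounds shown here, in a functional assay on PC-3 cells (Homo sapiens) for antiproliferative activity, read by WST assay, with a stated time of 3 days (a lower number here means a stronger inhibitor, a higher number a weaker inhibitor), compound 1 `COc1ccc(COC[C@@H]2C/C(C)=C/COCC/C=C/C(=O)C/C(C)=C\C=C\C(=O)O2)cc1` gives 7660 nM and holds the lower of the two numbers so far. Compound 2 `C/C1=C/C=C/C(=O)O[C@H](CO)C/C(C)=C/COCC/C=C/C(=O)C1`, with hydrogen in place of 4-methoxybenzyl on an oxygen on a saturated carbon, gives 16100 nM and sits higher. Compound 3 `COc1ccc(COC[C@H]2C/C(C)=C/COCC/C=C/C(=O)C/C(C)=C\C=C\C(=O)O2)cc1` has not yet been measured. Its change from compound 1 is the two compounds have the same atoms and bonds and differ only in configuration as drawn: 1 of 5 stereo elements differ; a stereocentre at a saturated ring carbon is drawn S in compound 1 and R in compound 3 and nothing else: a stereocentre at a saturated ring carbon is drawn S in compound 1 and R in compound 3. For the measured compounds named here, the only measured step is a 2.1-fold higher number from compound 1 to compound 2 (0.32 log units; beyond the scatter) and it is modest, but it alters a different place and leaves this stereocentre untouched. No measurement here shows what turning this centre does, so no direction can be favoured in this assay and no step beyond the scatter is expected. For compound 3 the estimate is 8000 nM (expected range 3000 nM to 20000 nM), an expected step (a 1.0-fold higher number from compound 1 to compound 3 (0.02 log units; within the scatter)) within the scatter.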

Compound 3, half-maximal inhibitory concentration: 6310 nM
Compound 3: the middle estimate sits 1.3-fold (0.10 log units) above what was measured; low and high end bracket the measured number.
By their numbers in this assay, from the lowest: compounds 3 and 1 (each within the scatter of the next); then compound 2.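

In this assay, turning the stereocentre at the saturated ring carbon gives a 1.2-fold lower number from compound 1 to compound 3 (0.08 log units; within the scatter), so for compounds carrying the 4-methoxybenzyl group, this read-out does not separate the S and R drawings of this carbon. Among the compounds shown here, the earlier step from compound 1 to compound 2 changed the group on the oxygen and left this centre alone, so this pair is the first to test the centre itself. The test is a clean one, and any effect of configuration at this carbon would have to show here: the fact that compounds 1 and 3 differ only in the configuration as drawn

Going by these compounds, whether configuration at this carbon matters as little with the free hydroxyl of compound 2, or with an amine or a carboxylic acid in place of the 4-methoxybenzyl group, stays open. The compounds shown also cannot tell whether this centre matters outside this assay.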